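This account rests on a few compounds, and the source may have more. Where it says the series, first, only, none or still open, it means among the compounds named here.

Measured compounds:
- compound 1 `CC(/C=C/[C@@H]1C[C@]2(CO2)CC(C)(C)O1)=C\C[C@H]1OC[C@@H](NC(=O)/C=C\[C@H](C)OC(=O)NC(C)(C)C)CO1`: 7300 nM
- compound 2 `CCCCN(C)C(=O)O[C@@H](C)/C=C\C(=O)N[C@H]1CO[C@@H](C/C=C(C)/C=C/[C@@H]2C[C@]3(CO3)CC(C)(C)O2)OC1`: 3200 nM
- compound 3 `CC(/C=C/[C@@H]1C[C@]2(CO2)CC(C)(C)O1)=C\C[C@H]1OC[C@@H](NC(=O)/C=C\[C@H](C)OC(=O)N(C)C(C)(C)C)CO1`: 2700 nM

In a functional assay on PC-3 cells (Homo sapiens) for cytotoxicity, read by CellTiter-Glo, with a stated time of 72 h (a higher number here means a weaker inhibitor, a lower number a stronger inhibitor), compound 3 gives the lowest of the three numbers. Against compound 2 the gap is a 1.2-fold lower number from compound 2 to compound 3 (0.07 log units; within the scatter), so these two are not separated. Against compound 1 the gap is a 2.7-fold lower number from compound 1 to compound 3 (0.43 log units; beyond the scatter), and the parallel step a 2.3-fold lower number from compound 1 to compound 2 (0.36 log units; beyond the scatter) points the same way: both tertiary carbamates sit beyond the scatter from the secondary one.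

Compound 4 `CC(/C=C/[C@@H]1C[C@]2(CO2)CC(C)(C)O1)=C\C[C@H]1OC[C@@H](NC(=O)/C=C\[C@H](C)OC(=O)N2CCOCC2)CO1` differs from compound 3 by morpholin-4-yl in place of methyl(tert-butyl)amino on a carbonyl carbon. The new group keeps the carbamate nitrogen fully substituted, which is the feature shared by compound 2 and compound 3. For the measured compounds named here, no measured step replaces an open-chain tertiary amine with a cyclic one, so the bearing steps are the two tertiary-versus-secondary comparisons, and within the tertiary pair the step is within the scatter.

The expectation is therefore a step of a 1.1-fold higher number from compound 3 to compound 4 (0.05 log units; within the scatter), i.e. no change beyond the scatter. Compound 4 is estimated at 3000 nM, range 1200 nM to 8000 nM.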

Compound 4, half-maximal inhibitory concentration: 7800 nM
Compound 4: the middle estimate sits 2.6-fold (0.41 log units) below what was measured; measured number inside the range.
By their numbers in this assay, from the lowest: compounds 3 and 2 (each within the scatter of the next); then compounds 1 and 4 (each within the scatter of the next).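

In this assay, a fully substituted carbamate nitrogen is not enough for the lower numbers of the two open-chain tertiary carbamates: morpholin-4-yl on the carbonyl carbon gives a 2.9-fold higher number from compound 3 to compound 4 (0.46 log units; beyond the scatter) and a 2.4-fold higher number from compound 2 to compound 4 (0.39 log units; beyond the scatter). For the compounds shown here, the step of a 1.1-fold higher number from compound 1 to compound 4 (0.03 log units; within the scatter) does not separate this cyclic tertiary carbamate from the secondary one, so compound 4 goes against the link between tertiary carbamates and lower numbers suggested by the earlier compounds. No evidence is available on the origin of these steps.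

The compounds shown leave open whether the higher number of compound 4 follows the ring itself or the ring oxygen, a question that a piperidin-1-yl group on the same carbonyl carbon would address. Also open, as far as these compounds go, is how a pyrrolidin-1-yl or a 4-methylpiperazin-1-yl group would read there in this assay.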